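Chain extension of the benzyl amide in a calpain-1 series

A few compounds are considered here, and "the series" means these few. Any claim that something is new, unique, unknown or untested is made for them only; others in the source may bear on it.

For the measured compounds named here, compound 2 `CCC(NC(=O)C(CC(C)C)NC(=O)OCc1ccccc1)C(=O)C(=O)NCc1ccccc1` gives 200 nM in an assay on isolated protein for inhibition of Calpain-1 catalytic subunit (Homo sapiens) (a lower number here means a stronger inhibitor, a higher number a weaker inhibitor), the lowest of the two numbers measured so far. Going by the values given here, its nearest neighbour, compound 1 `CCC(NC(=O)C(CC(C)C)NC(=O)OCc1ccccc1)C(=O)C(=O)NCC1CCCCC1`, gives 680 nM in this assay, and the step of a 3.4-fold lower number from compound 1 to compound 2 (0.53 log units; beyond the scatter) is the only measured step in the set. Compound 3 `CCC(NC(=O)C(CC(C)C)NC(=O)OCc1ccccc1)C(=O)C(=O)NCCCc1ccccc1` differs from compound 2 by phenethyl in place of phenyl on a saturated chain carbon bound to an amide-type nitrogen. Among the compounds with values here, no measured step covers a lengthening of this chain; the one step that does exist changes the ring, not the chain, so it bears only loosely on the new change. Because the step of a 3.4-fold lower number from compound 1 to compound 2 (0.53 log units; beyond the scatter) shows this position tolerates a change of group without a large swing, compound 3 is expected to stay close to compound 2, with a step of a 1.5-fold higher number from compound 2 to compound 3 (0.18 log units; within the scatter) that may lie within the scatter. Compound 3 is estimated at 300 nM, with a range from 120 nM to 800 nM.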

Compound 3, inhibition constant: 800 nM
Compound 3: middle estimate off by 2.7-fold (0.43 log units), on the low side, within the range that was stated.
By their numbers in this assay, from the lowest: compound 2; then compounds 1 and 3 (each within the scatter of the next).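

In this assay, the place on a saturated chain carbon bound to an amide-type nitrogen responds to chain length as well as to the ring: with the aromatic ring kept, lengthening gives a 4.0-fold higher number from compound 2 to compound 3 (0.60 log units; beyond the scatter) and so adds a second step beyond the scatter. The aromatic ring alone therefore does not secure the number of compound 2, since the comparison with the cyclohexyl compound shows a 1.2-fold higher number from compound 1 to compound 3 (0.07 log units; within the scatter) and leaves compound 2 as the only one of the three set apart. Nothing available here accounts for this sensitivity to chain length.

From the compounds shown here alone, what a 2-phenylethyl group would give at this place stays open, and with it whether the number climbs gradually with chain length. Also open, going by these compounds, is how an amine or a carboxylic acid on the phenyl ring of compound 2 would read.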